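The source may report more compounds than this note shows. Statements on the series, on what has been measured and on what is new or still open speak of the compounds shown alone.

Measured in a functional assay on cells (Homo sapiens) for antiproliferative activity, read by MTT assay, with a stated time of 48 h; a higher number here means a weaker inhibitor, a lower number a stronger inhibitor:
- compound 1 `CCN(CC)CCCn1c(N)c(-c2nc3ccccc3[nH]2)c2nc(C#N)c(C#N)nc21`: 28900 nM
- compound 2 `CCCCn1c(N)c(-c2nc3ccccc3[nH]2)c2nc(C#N)c(C#N)nc21`: > 50000 nM (a limit of the assay)

Among the measured compounds shown here, compound 1 holds the only actual number in this short series, 28900 nM, so there is no measured range to place it in. The result for compound 2 is a limit, > 50000 nM.

The next compound is compound 3 `CCN(CC)CCCn1c(N)c(-c2nc3cc(Cl)ccc3[nH]2)c2nc(C#N)c(C#N)nc21`, which differs from compound 1 as follows: chloro in place of hydrogen on an aromatic carbon. The change is chloro in place of hydrogen on an aromatic carbon, and the same difference reads 1H-benzimidazol-2-yl to 5-chloro-1H-benzimidazol-2-yl.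

For the measured compounds named here, the one measured step is an at least 1.7-fold higher number from compound 1 to compound 2 (0.23 log units; that floor lies within the scatter). It lies on a saturated chain carbon, not on an aromatic carbon, so it offers no size for this change. Going by the values given here, no measured step bears directly on the chloro change, and no shift beyond the scatter in this assay is expected in either direction. The expected step is a 1.2-fold lower number from compound 1 to compound 3 (0.08 log units; within the scatter). For compound 3 the estimated value is 24000 nM, with an expected range of 8000 nM to 50000 nM.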

Compound 3, half-maximal inhibitory concentration: 23200 nM
Compound 3: the middle estimate sits 1.0-fold (0.01 log units) above what was measured; low and high end bracket the measured number.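

Among the compounds shown here, compound 3 adds the first measured step on an aromatic carbon of the shared core: in this assay, chloro in place of hydrogen gives a 1.2-fold lower number from compound 1 to compound 3 (0.10 log units; within the scatter). Compound 1 and compound 3 cannot be told apart in this read-out, so with the diethylamino chain in place, this position accepts a chloro group and the result remains a measurable number. Compound 2 remains a limit of the assay rather than a number, and it gives no size for the chloro change: the limit of > 50000 nM in this assay, at which 1 of the 3 values shown sits.

On these data alone, the reading rests on a single chloro pair, so it remains open whether other groups at this position, such as methoxy, an amine or a carboxylic acid, would also stay within the scatter of compound 1 or would move the value beyond it. Also open, as far as these compounds go, is whether chloro would read the same with the chain of compound 2, or with a longer chain or a morpholine in place of the diethylamino group.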